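A few compounds are considered here, and "the series" means these few. Any claim that something is new, unique, unknown or untested is made for them only; others in the source may bear on it.

Compound 1, whose structure is `CC(C)=CCC[C@]1(C)/C=C/[C@@H](OC(=O)C=C(C)C)[C@](C)(O)/C=C/C(=O)/C(C=O)=C\C1`, is measured in a functional assay on MCF7 cells (Homo sapiens) for antiproliferative activity, read by MTT assay, with a stated time of 48 h (a higher number here means a weaker inhibitor, a lower number a stronger inhibitor), where it gives 12600 nM. Among the three compounds measured, that is the highest number, so compound 1 is the weakest inhibitor of the set. Compound 2, `CCN(CC)C/C1=C/C[C@](C)(CCC=C(C)C)/C=C/[C@@H](OC(=O)C=C(C)C)[C@](C)(O)/C=C/C1=O`, gives 130 nM, and compound 3, `CC(C)=CCC[C@]1(C)/C=C/[C@@H](OC(=O)C=C(C)C)[C@](C)(O)/C=C/C(=O)/C(CN2CCN(C)CC2)=C\C1`, gives 550 nM.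

Compound 4, `CSC(=S)OC/C1=C/C[C@](C)(CCC=C(C)C)/C=C/[C@@H](OC(=O)C=C(C)C)[C@](C)(O)/C=C/C1=O`, is not yet measured. It differs from compound 1 in one place: a group of 6 heavy atoms (3 carbon, 1 oxygen, 2 sulfur; no ring) in place of a group of 2 heavy atoms (1 carbon, 1 oxygen; no ring), on a double-bonded ring carbon.

Two measured steps start from the same formyl group on the same ring carbon. The change a 97-fold lower number from compound 1 to compound 2 (1.99 log units; beyond the scatter) and the change a 23-fold lower number from compound 1 to compound 3 (1.36 log units; beyond the scatter) both brought in a carbon bearing a nitrogen, and both lowered the number by a large margin. Compound 4 instead brings in a group of three carbons, one oxygen and two sulfurs, with no nitrogen, so neither step is a direct match. What the two steps do show is that replacing the formyl group on this ring carbon has twice led to a stronger inhibitor. A smaller gain than either amine is therefore expected, with wide uncertainty, giving an expected step of a 3.2-fold lower number from compound 1 to compound 4 (0.50 log units; beyond the scatter). For compound 4 in this assay the estimate is 4000 nM, within a range from 800 nM to 20000 nM.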

Compound 4, half-maximal inhibitory concentration: 900 nM
Beside the measured number, compound 4's estimate is 4.4-fold (0.65 log units) above it, within the range that was stated.
By their numbers in this assay, from the lowest: compound 2; then compounds 3 and 4 (each within the scatter of the next); then compound 1.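

In this assay, the step of a 14-fold lower number from compound 1 to compound 4 (1.15 log units; beyond the scatter) shows that replacing formyl on this double-bonded ring carbon can lower the number by a large margin without any nitrogen in the incoming group, which the two amines could not show. Keeping the saturated chain carbon and changing only what it carries gives a 1.6-fold higher number from compound 3 to compound 4 (0.21 log units; within the scatter), which lies within the scatter, so this nitrogen-free group cannot be told apart from 4-methylpiperazin-1-yl, whereas a 6.9-fold higher number from compound 2 to compound 4 (0.84 log units; beyond the scatter) is beyond the scatter and leaves it behind diethylamino. No measurement available here explains these differences.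

From the compounds shown here alone, what remains open is whether the gain comes from losing the formyl group or from what enters in its place, a question that a simple hydroxymethyl or methyl group on the same ring carbon would help to answer. Going by these compounds, it is also open whether the two sulfur atoms matter, which could be tested with an acetoxymethyl group, keeping the oxygen on the chain carbon and carrying no sulfur, or with a carboxylic acid at this place.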